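Acid to Ethyl Ester: An Expected Loss of Potency

The compounds below may be only part of what the source reports. "The series", "measured", "known", "first", "only" and "open" are said of these compounds alone.

Going by the values given here, in a functional assay on MCF7 cells (Homo sapiens) for cytotoxicity, read by MTT assay, with a stated time of 72 h (a lower number here means a stronger inhibitor, a higher number a weaker inhibitor), compound 2 `Cc1oc2ncnc(Nc3cccc(Cl)c3)c2c1C(=O)O` gives 57500 nM, the only exact number so far. Compound 1 `CCOC(=O)c1c(C)oc2ncnc(Nc3cccc(C)c3)c12` gives > 1000000 nM, which is a limit and not a number. Compound 3 `CCOC(=O)c1c(C)oc2ncnc(Nc3cccc(Cl)c3)c12` changes carboxy to ethoxycarbonyl, with ethyl in place of hydrogen on an oxygen next to a carbonyl group. Guided by compound 1 at > 1000000 nM, a step toward weaker inhibition, beyond the usual scatter, is expected in this assay. The estimated change is a 2.6-fold higher number from compound 2 to compound 3 (0.42 log units; beyond the scatter). Compound 3 is expected at 150000 nM, with an estimated range of 15000 nM to 1000000 nM.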

Compound 3, half-maximal inhibitory concentration: > 1000000 nM
Compound 3 ended at the assay's limit; the forecaster's own chance of this, stated with the estimate: 40%; middle value at least 6.6-fold (0.82 log units) from the limit.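

Ethyl in place of hydrogen on an oxygen next to a carbonyl group gives an at least 17-fold higher number from compound 2 to compound 3 (1.24 log units; beyond the scatter) in this assay. Going by these compounds alone, this is the first comparison that isolates this position, and it shows that this single change is enough to reach a limit of the assay, which is not a true number: the limit of > 1000000 nM in this assay, at which 2 of the 3 values shown sit. The step for chloro in place of methyl on an aromatic carbon cannot be read. On these data alone, whether the carboxy group itself matters, or only the added ethyl, stays open; a methyl ester or a primary amide in the same place would help to separate the two.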